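Compound 3 to compound 4: ethyl becomes isobutyl

The source may report more compounds than this note shows. Statements on the series, on what has been measured and on what is new or still open speak of the compounds shown alone.

In an ADME assay (liver) for metabolic stability, with Liver microsome (Rattus norvegicus) as the target, read by LC-MS, using microsomes and NADPH, with stated times of 5 min and 60 min, tested at 4 uM (on this read-out lower numbers stand for a less stable compound and higher numbers for a more stable compound), compound 3 `CCC(=O)c1ccc(OCCCCOc2ccc(F)c(C(=O)O)c2)c(C)c1O` gives 35% and stands in the middle of the three measured compounds. Compound 1 `Cc1ccc(C(=O)O)cc1OCCCCOc1ccc(C(=O)CC(C)C)c(O)c1C` lies lower at 21% and compound 2 `Cc1cc(OCCCCOc2ccc(C(=O)CC(C)C)c(O)c2C)ccc1C(=O)O` lies higher at 57% with both gaps to compound 3 beyond the usual scatter.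

Compound 4 `Cc1c(OCCCCOc2ccc(F)c(C(=O)O)c2)ccc(C(=O)CC(C)C)c1O` differs from compound 3 by a single change (isopropyl in place of methyl on a saturated chain carbon bound to a carbonyl carbon), isopropyl in place of methyl on a saturated chain carbon bound to a carbonyl carbon. Among the compounds with values here, the only measured step (a number 36 percentage points higher from compound 1 to compound 2 (beyond the scatter)) is large, but it leaves this chain untouched, so no measurement tests the change directly. Compound 1 and compound 2 both carry isobutylcarbonyl already, and their wide gap makes the estimate uncertain. Compound 1 (21%) is the closer structural match to compound 4, which tilts the expectation slightly downward. The expected change in this assay is small and within the scatter (a number 8 percentage points lower from compound 3 to compound 4 (within the scatter)). For compound 4 the estimated value is 27% with an expected range from 12% to 45% in this assay.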

Compound 4, percent of the compound remaining: 59%
Estimate against measurement, compound 4: 32 percentage points below; measured number above the stated range.
By their numbers in this assay, from the lowest: compound 1; then compound 3; then compounds 2 and 4 (each within the scatter of the next).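

In this assay, within the data shown here, the chain is tested directly for the first time: with the 3-carboxy-4-fluorophenyl group held constant, isopropyl in place of methyl on a saturated chain carbon bound to a carbonyl carbon gives a number 24 percentage points higher from compound 3 to compound 4 (beyond the scatter) and so moves the read-out on its own. With isobutylcarbonyl held constant, 3-carboxy-4-fluorophenyl in place of 4-carboxy-3-methylphenyl gives a number 2 percentage points higher from compound 2 to compound 4 (within the scatter) while the same group in place of 5-carboxy-2-methylphenyl gives a number 38 percentage points higher from compound 1 to compound 4 (beyond the scatter) and so the effect of this group depends on which one it replaces. No supporting measurement bears on why these numbers moved.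

From the compounds shown here alone, whether a longer chain or a cyclopropyl group at this place would extend the step remains open. So does whether an amide in place of the carboxylic acid would keep the number of compound 4.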